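Replacing the benzylamino group with a hydroxypiperidine ring

The source may report more compounds than this note shows. Statements on the series, on what has been measured and on what is new or still open speak of the compounds shown alone.

Measured so far:
Compound 1 `O=c1cc(-c2c[nH]c3ncccc23)nc(Nc2ccccc2)[nH]1`: 443 nM
Compound 2 `O=c1cc(-c2c[nH]c3ncccc23)nc(NCc2ccccc2)[nH]1`: 122 nM

Both compounds were tested in a functional assay on HCT-116 cells (Homo sapiens) for cytotoxicity, with a stated time of 3 days; on this read-out lower numbers stand for an effect already at smaller amounts and higher numbers for an effect only at larger amounts of compound. Compound 1 gives 443 nM, and compound 2 gives 122 nM. Among the measured compounds shown here, the one step measured, a 3.6-fold lower number from compound 1 to compound 2 (0.56 log units; beyond the scatter), shows that swapping phenyl for benzyl on the nitrogen moved the number down by a modest amount that is beyond the scatter. For the measured compounds named here, compound 2 therefore holds the lowest number of the two, with compound 1 the only neighbour for comparison.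

Compound 3 `O=c1cc(-c2c[nH]c3ncccc23)nc(N2CCC(O)CC2)[nH]1` is not yet measured. It differs from compound 2 as follows: 4-hydroxypiperidin-1-yl in place of benzylamino on an aromatic carbon. Here the aromatic ring of the benzyl group and the amine hydrogen both disappear, and a saturated ring carrying a hydroxyl group takes their place. Going by the values given here, no measured step covers such a change; the only step known, from compound 1 to compound 2, concerns aromatic substituents on the nitrogen and does not tell how a saturated ring behaves here. The expectation for compound 3 is therefore uncertain, and a somewhat higher number than compound 2 is expected, a 3.3-fold higher number from compound 2 to compound 3 (0.52 log units; beyond the scatter). The estimate for compound 3 is 400 nM, with a range from 80 nM to 2000 nM.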

Compound 3, half-maximal effective concentration: 6190 nM
Estimate against measurement, compound 3: 15-fold (1.19 log units) below, outside the stated range (above it).
By their numbers in this assay, from the lowest: compound 2; then compound 1; then compound 3.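

In this assay, the group on this aromatic carbon turns out to matter much more than the first pair suggested: 4-hydroxypiperidin-1-yl in place of benzylamino gives a 51-fold higher number from compound 2 to compound 3 (1.71 log units; beyond the scatter), a far larger shift than a 3.6-fold lower number from compound 1 to compound 2 (0.56 log units; beyond the scatter) seen on going from anilino to benzylamino. The same replacement made against anilino gives a 14-fold higher number from compound 1 to compound 3 (1.15 log units; beyond the scatter), so among these three compounds, both groups carrying a carbon-only aromatic ring give lower numbers than the saturated ring with its hydroxyl. Nothing available explains this rise, so the result stays a plain observation about these three compounds.

The single change removes the aromatic ring, adds a hydroxyl and replaces the amine hydrogen all at once, and the compounds shown cannot tell these parts apart. As far as these compounds go, a plain piperidin-1-yl group would show what the hydroxyl contributes, while a cyclohexylmethylamino group would test a saturated ring that keeps the amine hydrogen, and how either would read in this assay remains open.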